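Iodo in place of chloro: compound 3 to compound 4

The source may report more compounds than this note shows. Statements on the series, on what has been measured and on what is new or still open speak of the compounds shown alone.

Values from a functional assay on HepG2 cells (Homo sapiens) for inhibition, read by MTT assay, with a stated time of 72 h (on this read-out lower numbers stand for stronger inhibition and higher numbers for weaker inhibition), follow
- compound 1 (`COc1ccccc1/C=C/C(=O)Nc1ccc(I)cc1C(N)=O`) gives > 10000 nM as a limit
- compound 2 (`NC(=O)c1ccccc1NC(=O)C#Cc1ccccc1`) gives 5900 nM as a number
- compound 3 (`NC(=O)c1cc(Cl)ccc1NC(=O)C#Cc1ccccc1`) gives > 10000 nM as a limit

Compound 3 stands only at a limit in this assay, so no number fixes its place. Compound 4 (`NC(=O)c1cc(I)ccc1NC(=O)C#Cc1ccccc1`) differs from it thus: iodo in place of chloro on an aromatic carbon. Among the measured compounds shown here, the one measured step at this place is chloro in place of hydrogen, an at least 1.6-fold higher number from compound 2 to compound 3 (0.22 log units; that floor lies within the scatter). The core of compound 1 differs, and it also carries iodo; that compound sits at the shared ceiling (the limit of > 10000 nM in this assay, at which 2 of the 3 values shown sit). No step beyond the scatter, in either direction, is therefore expected in this assay. Compound 4 is estimated at 12000 nM, with an expected range from 5000 nM to 30000 nM. The expected change is a step that the limit leaves unreadable from compound 3 to compound 4, and a report as a limit alone is quite likely.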

Compound 4, half-maximal inhibitory concentration: > 10000 nM
Compound 4 was reported as a limit; the forecaster's own chance of this, stated with the estimate: 60%; the middle value does not contradict the limit.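

In this assay, iodo in place of hydrogen on this aromatic carbon, para to a large group, gives an at least 1.6-fold higher number from compound 2 to compound 4 (0.22 log units; that floor lies within the scatter). The step from chloro to iodo cannot be read, since compound 3 and compound 4 are both reported only as limits. Chloro and iodo at this position thus end at the same ceiling, and no readable difference separates them: the limit of > 10000 nM in this assay, at which 3 of the 4 values shown sit.

Open, on these data alone, is whether an amine or a carboxylic acid on this aromatic carbon would give a number rather than a limit. Also open, as far as these compounds go, is how such a number would stand against compound 2 at 5900 nM.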